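The source may report more compounds than this note shows. Statements on the series, on what has been measured and on what is new or still open speak of the compounds shown alone.

Measured so far in a functional assay on aorta (Rattus norvegicus, strain Sprague-Dawley) for inhibition; a higher number here means that more compound is needed for the effect, a lower number that less compound is needed:
compound 1, `C=C=CCOc1cc2c(c3c1C[C@@H]1[C@@H](C)CO[C@]1(C)O3)C[C@@H]1[C@@H](C)CO[C@]1(C)O2` — 11000 nM
compound 2, `CC1COC2(C)Oc3c(c4c(c5c3CC3C(C)COC3(C)O5)CC3C(C)COC3(C)O4)CC12` — 11000 nM
compound 3, `C[C@H]1CO[C@]2(C)Oc3c(c4c(c5c3C[C@@H]3[C@@H](C)CO[C@]3(C)O5)C[C@@H]3[C@@H](C)CO[C@]3(C)O4)C[C@H]12` — 31000 nM

Compound 1 and compound 2 give the same number at the digits shown, and these two stand together at the bottom of the three values. Compound 3 gives the highest number of the three. Among the compounds with values here, the only single-change step among the measured compounds is a 2.8-fold higher number from compound 2 to compound 3 (0.45 log units; beyond the scatter), and the evidence that accompanies it is the fact that one of compounds 2 and 3 is drawn with a defined configuration and the other without, at the place where they differ; this step concerns the drawing of stereocentres on the shared core and not a change of any group on it.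

Compound 4, `C#CCOc1cc2c(c3c1C[C@@H]1[C@@H](C)CO[C@]1(C)O3)C[C@@H]1[C@@H](C)CO[C@]1(C)O2`, differs from compound 1 in one place: ethynyl in place of propa-1,2-dien-1-yl on a saturated chain carbon bound to an oxygen on an aromatic ring. Within the data shown here, no measured step addresses a change of this kind, since the one step that exists is a stereochemical one between compound 2 and compound 3 and says nothing about the chain on the oxygen on the aromatic ring. With nothing to point either way, compound 4 is expected to give a number in this assay close to that of compound 1, so that no change at the digits printed from compound 1 to compound 4 (within the scatter) is expected to remain within the scatter. For compound 4 the estimate in this assay is 11000 nM, with a range from 5000 nM to 25000 nM.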

Compound 4, half-maximal effective concentration: 22000 nM
Estimate against measurement, compound 4: 2.0-fold (0.30 log units) below; measured number inside the range.
By their numbers in this assay, from the lowest: compounds 1, 2, 4 and 3 (each within the scatter of the next, the first and the last beyond it).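

In this assay, within the data shown here, replacing propa-1,2-dien-1-yl with ethynyl on a saturated chain carbon bound to an oxygen on an aromatic ring gives a 2.0-fold higher number from compound 1 to compound 4 (0.30 log units; within the scatter), the first measured step that concerns this chain and not the drawing of stereocentres on the shared core. Read on its own, this step shows that the two groups are not separated beyond the scatter, so that going from (buta-2,3-dien-1-yl)oxy to propargyloxy, with a double-bond pair giving way to one triple bond and the chain losing a carbon, leaves the number in this assay without a change that can be told from repeat measurement. The information at hand about the stereochemical pair of compounds has no bearing on this chain, and nothing measured accounts for the result.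

As far as these compounds go, whether an amine, a carboxylic acid or a longer chain such as hexyl on the same oxygen would shift the number beyond the scatter stays open, since the two chains compared here are both short and hold only carbon. Also open, from the compounds shown here alone, is whether a saturated propyl chain would sit with these two groups or apart from them.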